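The source may hold more compounds than are shown below. What is called first, only, known or untested is meant among the compounds shown, and "the series" means these compounds.

Compound 1 `Nc1cc(N)c2nc(-c3ccccc3)c(Oc3ccc(Cl)c(Cl)c3)nc2c1`: 17000 nM
Compound 2 `COc1ccc(CNc2nc3cc(N)cc(N)c3nc2-c2ccccc2)cc1OC`: 14800 nM
Compound 3 `COc1cc(CNc2nc3cc(N)cc(N)c3nc2-c2ccccc2)cc(OC)c1OC`: 2950 nM

These three compounds share one core and were all tested in a functional assay on SF-268 cells (Homo sapiens) for inhibition, read by sulforhodamine B assay, with a stated time of 48 h; a lower number here means a stronger inhibitor of growth, a higher number a weaker inhibitor of growth. Compound 1 has the highest number of the three; compound 2 stands within the scatter of it, so no order can be read between those two, while compound 3 lies beyond the scatter below compound 1. Within the data shown here, the only single-point step among the measured compounds is a 5.0-fold lower number from compound 2 to compound 3 (0.70 log units; beyond the scatter), which adds a methoxy to the side chain of compound 2.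

Compound 4 `Nc1cc(N)c2nc(-c3ccccc3)c(Sc3ccc(F)cc3)nc2c1` is the unmeasured analogue of compound 1. The change is (4-fluorophenyl)sulfanyl in place of 3,4-dichlorophenoxy on an aromatic carbon. Among the measured compounds shown here, no measured step bears on this change: the step from compound 2 to compound 3 concerns a different substituent at a different place, and no pair among the measured compounds swaps the group at this position. The account therefore rests on compound 1 alone, and a step of no clear direction, likely within the scatter, is expected in this assay, with the estimate widened to reflect how little is known. The expected step is a 1.3-fold lower number from compound 1 to compound 4 (0.12 log units; within the scatter). Compound 4 is thus estimated at 13000 nM, with a range from 3500 nM to 45000 nM.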

Compound 4, concentration for 50% growth inhibition: 17800 nM
Beside the measured number, compound 4's estimate is 1.4-fold (0.14 log units) below it, and the stated range covers the measured number.
By their numbers in this assay, from the lowest: compound 3; then compounds 2, 1 and 4 (each within the scatter of the next).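

In this assay, among these compounds, putting (4-fluorophenyl)sulfanyl in place of 3,4-dichlorophenoxy on the aromatic carbon next to the ring nitrogen gives a 1.0-fold higher number from compound 1 to compound 4 (0.02 log units; within the scatter), the only measured step at this position of the shared core. No order can therefore be read between these two groups here, even though the swap alters both the atom linking the aromatic ring to the core and the halogens on that ring, so the two alterations are not separated by this pair. No measured property of either group accompanies this result, so the data offer no explanation for it.

The compounds shown leave open what each alteration would do alone, as a sulfur link carrying the 3,4-dichlorophenyl group or an oxygen link carrying the 4-fluorophenyl group would be needed to tell them apart. They also leave open whether a group of a different kind at this position, such as a morpholine, a carboxylic acid or a longer alkyl chain, would stand apart from these two in this assay.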